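Dichloro-anilino analogue in the shared thienopyrimidinone series

This account rests on a few compounds, and the source may have more. Where it says the series, first, only, none or still open, it means among the compounds named here.

Measured compounds:
compound 1, `Cc1nc2sc(Nc3ccc(Cl)cc3)nc2c(=O)[nH]1`: 33%
compound 2, `Cc1nc2sc(Nc3cccc(Cl)c3)nc2c(=O)[nH]1`: 44%

In an assay on CHO cells for displacement of a labelled ligand from adenosine receptor A1 (Homo sapiens), read by scintillation counting, with a stated time of 120 min, tested at 1 uM (a lower number here means less inhibition, a higher number more inhibition at the concentration tested (going by the name of the read-out)), compound 2 gives 44%, the higher of the two numbers recorded so far; its nearest neighbour is compound 1, whose number is lower by a gap beyond the usual scatter. Within the data shown here, no single-site step between measured compounds is defined here, so the two values are simply compared side by side.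

Compound 3, `Cc1nc2sc(Nc3ccc(Cl)c(Cl)c3)nc2c(=O)[nH]1`, has not yet been measured in this assay. Relative to compound 2 the change is chloro in place of hydrogen on an aromatic carbon. Since both measured compounds carry a single chloro on the aniline and compound 3 carries two, the expectation is a step of a number 4 percentage points higher from compound 2 to compound 3 (within the scatter) that is small and upward, probably not beyond the scatter. For compound 3 the estimated inhibition in this assay is 48%, with a range from 25% to 70%.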

Compound 3, a percentage reported as inhibition, at one concentration (the size of the read-out at that concentration, not a potency): 30%
Compound 3: the middle estimate sits 18 percentage points above what was measured; measured number inside the range.
By their numbers in this assay, from the lowest: compounds 3 and 1 (each within the scatter of the next); then compound 2.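

Chloro in place of hydrogen on an aromatic carbon, ortho to a chloro group and para to a large group, gives a number 14 percentage points lower from compound 2 to compound 3 (beyond the scatter) in this assay, so on this six-membered aromatic ring a second chloro does not raise the read-out when added to compound 2. Read from the other monochloro compound, the same kind of change gives a number 3 percentage points lower from compound 1 to compound 3 (within the scatter), so adding chloro has no readable effect there and the outcome depends on which compound it is added to. Nothing measured on hand explains the drop from compound 2. 

From the compounds shown here alone, whether a fluoro, a methyl or a methoxy group at this place would follow chloro stays open. Going by these compounds, all three numbers are readings at a single concentration, so how potency shifts across these compounds also stays open.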